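The compounds below may be only part of what the source reports. "The series", "measured", "known", "first", "only" and "open" are said of these compounds alone.

Of the compounds shown here, three share a common core and have been tested in a functional assay on the whole organism (plasma, strain Wistar) with Rattus norvegicus as the target, with a stated time of 15 days, at a dose of 100 mg/kg by the oral route; a lower number here means a weaker effect, a higher number a stronger effect of the compound at the dose given. Compound 1, with the structure `Cc1nc(COc2ccc(/C=C3\SC(=O)NC3=O)cc2)cs1`, gives 22.9% in this assay. Compound 2, with the structure `O=C1NC(=O)/C(=C/c2ccc(OCCSc3nnc(-c4ccc([N+](=O)[O-])cc4)[nH]3)cc2)S1`, gives 18%. Compound 3, with the structure `O=C1NC(=O)/C(=C/c2ccc(OCCSc3nnc(-c4ccccc4[N+](=O)[O-])[nH]3)cc2)S1`, gives 26.8%. For the measured compounds named here, the only pair that differs in a single place is compound 2 and compound 3, where the change is 2-nitrophenyl in place of 4-nitrophenyl on an aromatic carbon; the resulting step is a number 8.8 percentage points higher from compound 2 to compound 3 (within the scatter), which lies within the scatter. Compound 3 thus shows the highest of the three numbers, yet its readings against compound 1 and compound 2 are both within the scatter, so no ordering among the three can be claimed.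

Compound 4, with the structure `COc1ccc(-c2nnc(SCCOc3ccc(/C=C4\SC(=O)NC4=O)cc3)[nH]2)cc1`, is not yet measured. It differs from compound 3 as follows: 4-methoxyphenyl in place of 2-nitrophenyl on an aromatic carbon. Going by the values given here, the one measured step at this aromatic carbon moved a nitro group between positions and stayed within the scatter; no measured step replaces the nitro-bearing ring with a methoxy-bearing one, so there is no direct guide. On that basis the step of a number 1.8 percentage points lower from compound 3 to compound 4 (within the scatter) is expected to stay within the scatter. Compound 4 is therefore estimated to give about 25%, with a range from 12% to 38%.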

Compound 4, a percentage reported as activity, at one dose (the size of the read-out at that dose, not a potency): 43.4%
Compound 4: middle estimate off by 18.4 percentage points, on the low side, and the stated range ends below it.
By their numbers in this assay, from the lowest: compounds 2, 1 and 3 (each within the scatter of the next); then compound 4.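

The aromatic carbon on the five-membered ring now shows that a change here can exceed the scatter: in this assay, 4-methoxyphenyl in place of 2-nitrophenyl gives a number 16.6 percentage points higher from compound 3 to compound 4 (beyond the scatter). Methoxy in place of nitro on the same phenyl ring, with the 4-substitution kept, gives a number 25.4 percentage points higher from compound 2 to compound 4 (beyond the scatter), so compound 4 stands clear of both nitrophenyl compounds, whereas the earlier shift of the nitro group alone stayed within the scatter. The identity of the group on this phenyl ring therefore matters in this series, but no measured information explains why the methoxy compound gives the higher number.

On these data alone, with only nitro and methoxy in hand, it remains open whether the higher number comes from having methoxy or simply from losing nitro, a question that plain phenyl, 4-chlorophenyl or 4-aminophenyl at this carbon could help to settle. As far as these compounds go, it is also open whether methoxy depends on where it sits on the phenyl ring, which 2-methoxyphenyl would test, and whether a larger ethoxy group would hold the same level.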